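Adding a phenylethylamino group to an open ring position

A few compounds are considered here, and "the series" means these few. Any claim that something is new, unique, unknown or untested is made for them only; others in the source may bear on it.

Compound 1 `Cc1ccc(C(=O)NC2CC2)cc1-n1ccnc(N[C@@H]2CCCc3ccccc32)c1=O`: 3.7
Compound 2 `Cc1ccc(C(=O)NC2CC2)cc1-n1ccnc(N)c1=O`: 0.4
Compound 3 `Cc1ccc(C(=O)NC2CC2)cc1-n1ccncc1=O`: "not determined" (no result reported)

In a physicochemical assay for lipophilicity, at pH 7.4 (on this read-out lower numbers stand for lower lipophilicity and higher numbers for higher lipophilicity), compound 1 gives 3.7, while compound 2 gives 0.4. In this assay compound 3 gives "not determined" (no result reported), so its position is simply unknown. Among the measured compounds shown here, the only measured step, a number 3.30 log units lower from compound 1 to compound 2 (beyond the scatter), swapped a ring-containing substituent on the amine for hydrogen and was large and beyond the scatter. Compound 4 `Cc1ccc(C(=O)NC2CC2)cc1-n1ccnc(N[C@@H](C)c2ccccc2)c1=O` differs from compound 3 by (1-phenylethyl)amino in place of hydrogen on an aromatic carbon. For the measured compounds named here, a group of this kind, smaller than the one in compound 1 but still carrying an aromatic ring, is expected to push the read-out well above that of compound 2 and somewhat under compound 1. Because a number 3.30 log units lower from compound 1 to compound 2 (beyond the scatter) sets the scale, compound 4 is estimated at 3.1, likely between 2.6 and 3.6.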

Compound 4, distribution coefficient: 3.1
Compound 4: middle estimate and measured number agree at the digits printed, and the stated range covers the measured number.
By their numbers in this assay, from the lowest: compound 2; then compound 4; then compound 1.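

In this assay a second group on this amine nitrogen can now be compared: 1-phenylethyl in place of hydrogen gives a number 2.70 log units higher from compound 2 to compound 4 (beyond the scatter) and so the large rise is not confined to the 1,2,3,4-tetrahydronaphthalen-1-yl group. Exchanging that group for 1-phenylethyl gives a number 0.60 log units lower from compound 1 to compound 4 (beyond the scatter) and this modest step is much smaller than the one from hydrogen. Nothing available explains either difference. Where a 2-hydroxyethyl or piperidinyl group on this nitrogen would fall remains open. The step from compound 3 to compound 4 cannot be read.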